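Phenyl for Methyl on the Ring Nitrogen, Second Instance

This account rests on a few compounds, and the source may have more. Where it says the series, first, only, none or still open, it means among the compounds named here.

Compound 1 `COC(=O)c1c(O)c2ccccc2n(C)c1=O` was tested in a functional assay, with a stated time of 20 min, tested at 0.5 mM (on this read-out lower numbers stand for a weaker effect and higher numbers for a stronger effect at the one concentration tested), and gives 17.5%. Compound 2 `COC(=O)c1c(O)c2ccccc2n(-c2ccccc2)c1=O` differs from it by phenyl in place of methyl on an aromatic nitrogen, and in this assay compound 2 gives 16.8%; the step is a number 0.7 percentage points lower from compound 1 to compound 2 (within the scatter). Compound 3 `Cn1c(=O)c(C(=O)NCCCCCCN)c(O)c2ccccc21` carries a different core, and how it differs from compound 1 is not broken down here. In this assay compound 3 gives 13.7%, a number within the scatter of both compound 1 and compound 2. Compound 4 `NCCCCCCNC(=O)c1c(O)c2ccccc2n(-c2ccccc2)c1=O` differs from compound 3 by phenyl in place of methyl on an aromatic nitrogen. This is the same kind of change as that from compound 1 to compound 2, though the surroundings are not identical: in compound 1 the place is meta to a methoxycarbonyl group, while in compound 3 it is meta to a large group. Because a number 0.7 percentage points lower from compound 1 to compound 2 (within the scatter) lay within the scatter, the expected step for compound 4 is likewise small, a number 0.2 percentage points lower from compound 3 to compound 4 (within the scatter). Compound 4 is therefore estimated to give 13.5% in this assay, between 5% and 24%.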

Compound 4, a percentage reported as activity, at one concentration (the size of the read-out at that concentration, not a potency): 19.3%
The estimate for compound 4 lay 5.8 percentage points below the measured number; measured number inside the range.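

In this assay, the new step for phenyl in place of methyl on an aromatic nitrogen is a number 5.6 percentage points higher from compound 3 to compound 4 (within the scatter) and, set beside the earlier step, does not differ from it: the same change on two cores in this assay, a number 0.7 percentage points lower (within the scatter) from compound 1 to compound 2 and a number 5.6 percentage points higher (within the scatter) from compound 3 to compound 4, 6.3 percentage points apart, within the scatter of two such steps. With phenyl held fixed, (6-aminohexyl)amino in place of methoxy on a carbonyl carbon gives a number 2.5 percentage points higher from compound 2 to compound 4 (within the scatter) and so also stays inside the usual spread of this read-out. The change therefore carries from the core of compound 1 to the core of compound 3 without a distinguishable effect on this read-out, but two pairs read at one concentration do not show that it would behave the same way at other concentrations or on other cores.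

The compounds shown carry only methyl or phenyl on the ring nitrogen, and only methoxy or (6-aminohexyl)amino on the carbonyl carbon. On these data alone, whether a benzyl group on that nitrogen, or a carboxylic acid or a longer aminoalkyl chain on the carbonyl carbon, would move the number beyond the scatter remains open.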